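A few compounds are considered here, and "the series" means these few. Any claim that something is new, unique, unknown or untested is made for them only; others in the source may bear on it.

Compound 1 `NS(=O)(=O)NCC1CCN(c2cc(-c3cccc(Cl)c3)ncn2)CC1` and compound 2 `NS(=O)(=O)NCC1CCN(c2cc(-c3ccccc3Cl)ncn2)CC1` share one core and differ only in their chlorophenyl group. In a functional assay on MCF7 cells (Homo sapiens) for antiproliferative activity, read by sulforhodamine B assay, with a stated time of 48 h (on this read-out higher numbers stand for weaker inhibition of growth and lower numbers for stronger inhibition of growth), compound 1 gives 47100 nM, while compound 2 gives 62400 nM; the step of a 1.3-fold higher number from compound 1 to compound 2 (0.12 log units; within the scatter) stays within the scatter. Of the two numbers, that of compound 1 is the smaller, but the gap to compound 2 does not exceed the scatter, so no order can be read from it. Compound 3 `NS(=O)(=O)NCCC1CCN(c2cc(-c3cccc(Cl)c3)ncn2)CC1` keeps the aromatic part of compound 1 and alters the chain: (sulfamoylamino)methyl in place of sulfamoylamino on a saturated chain carbon bound to a saturated ring carbon. Among the compounds with values here, no measured step addresses this change; the only step in hand, a 1.3-fold higher number from compound 1 to compound 2 (0.12 log units; within the scatter), concerns the chlorophenyl group and was within the scatter. The account therefore expects a step of a 1.0-fold lower number from compound 1 to compound 3 (0.00 log units; within the scatter) in this assay, none beyond the scatter. Compound 3 is estimated at 47000 nM, within a range of 20000 nM to 110000 nM.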

Compound 3, concentration for 50% growth inhibition: 31200 nM
Compound 3: the middle estimate sits 1.5-fold (0.18 log units) above what was measured; low and high end bracket the measured number.
By their numbers in this assay, from the lowest: compounds 3, 1 and 2 (each within the scatter of the next).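

Replacing sulfamoylamino with (sulfamoylamino)methyl on a saturated chain carbon bound to a saturated ring carbon gives a 1.5-fold lower number from compound 1 to compound 3 (0.18 log units; within the scatter) in this assay. Within the data shown here, this is the first reading at this position, and it shows that this change to the chain, like the earlier change in the chlorophenyl group, leaves the number within the scatter, so no order can be read from it. No experimental finding is available to explain this result.

The compounds shown leave open whether a longer chain, such as 3-(sulfamoylamino)propyl, would give a step beyond the scatter, or whether an amine or a carboxylic acid in place of the sulfamoylamino group would do so. They also leave open whether the same chain change would give a similar step with the 2-chlorophenyl group of compound 2.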